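The compounds below may be only part of what the source reports. "The series", "measured", "known", "first", "only" and "open" are said of these compounds alone.

Compound 1 `CN(C)CCN(CCN(C)C)c1cccc(C(=O)N2CCc3ccc(OS(N)(=O)=O)cc3C2)c1` gives 0% in an assay on HEK293 cells for inhibition of Steryl-sulfatase (Homo sapiens), tested at 0.1 uM (on this read-out higher numbers stand for a stronger effect at the one concentration tested and lower numbers for a weaker effect), and stands lowest of the two numbers in hand; compound 2 `CN(C)CCN(Cc1ccccc1)c1ccc(C(=O)N2CCc3ccc(OS(N)(=O)=O)cc3C2)cc1` gives 13.9% in this assay, a number higher by more than the scatter, though the two structures differ in more than one place, so only the two values themselves are noted. Compound 3 `CN(CCCN1CCCCC1)c1cccc(C(=O)N2CCc3ccc(OS(N)(=O)=O)cc3C2)c1` is not yet measured. It differs from compound 1 as follows: methyl(3-(piperidin-1-yl)propyl)amino in place of bis(2-(dimethylamino)ethyl)amino on an aromatic carbon. Among the compounds with values here, no step between measured compounds covers this change. The step of a number 5 percentage points higher from compound 1 to compound 3 (within the scatter) is expected to stay within the scatter, with compound 3 estimated at 5% in this assay, in the range 0% to 20%.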

Compound 3, a percentage reported as inhibition, at one concentration (the size of the read-out at that concentration, not a potency): 24.1%
Estimate against measurement, compound 3: 19.1 percentage points below, outside the stated range (above it).
By their numbers in this assay, from the lowest: compound 1; then compound 2; then compound 3.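

Methyl(3-(piperidin-1-yl)propyl)amino in place of bis(2-(dimethylamino)ethyl)amino on an aromatic carbon, meta to a large group, raises the read-out in this assay (a number 24.1 percentage points higher from compound 1 to compound 3 (beyond the scatter)). This position therefore responds to the group it carries, even with 11 heavy atoms in both groups. No measurement on hand accounts for the step.

Within the data shown here, the single step changes the ring, the chain and the number of amine nitrogens together, so their shares remain open. A morpholine ring or a two-carbon chain at this position could help to separate them.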